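Swapping phenyl for hexyl on the shared core

The compounds below may be only part of what the source reports. "The series", "measured", "known", "first", "only" and "open" are said of these compounds alone.

Measured in an ADME assay on U2OS cells (Homo sapiens) for cytotoxicity; on this read-out higher numbers stand for lower toxicity in this test and lower numbers for higher toxicity in this test:
- compound 1 `CCCCCCCCc1ccc(C(=O)N/N=C/c2ccc([N+](=O)[O-])o2)cc1`: > 200000 nM, a limit of the assay and not a number
- compound 2 `CCCCNc1ccc(C(=O)N/N=C/c2ccc([N+](=O)[O-])o2)cc1`: 12000 nM
- compound 3 `O=C(N/N=C/c1ccc([N+](=O)[O-])o1)c1ccc(-c2ccccc2)cc1`: 109000 nM

Of the two exact numbers, the higher belongs to compound 3, with a 9.1-fold higher number from compound 2 to compound 3 (0.96 log units; beyond the scatter). Compound 4 `CCCCCCc1ccc(C(=O)N/N=C/c2ccc([N+](=O)[O-])o2)cc1` carries hexyl in place of phenyl on an aromatic carbon. The closest guide is the octyl chain, with an at least 1.8-fold lower number from compound 1 to compound 3 (0.26 log units; that floor lies within the scatter). That step rests on a limit, and its floor lies within the scatter. The large step, an at least 16-fold lower number from compound 1 to compound 2 (1.22 log units; beyond the scatter), involves butylamino, which is absent here, so it bears less directly. In this assay, no step beyond the scatter is therefore expected, though any shift would more likely be upward. The expected change is a 1.3-fold higher number from compound 3 to compound 4 (0.11 log units; within the scatter). For compound 4, the estimated value is 140000 nM, with an expected range of 60000 nM to 200000 nM.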

Compound 4, half-maximal cytotoxic concentration: > 200000 nM
Compound 4: a limit, no number; the forecaster's own chance of this, stated with the estimate: 30%; middle value at least 1.4-fold (0.15 log units) from the limit.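

In this assay, compound 4 gives > 200000 nM, a limit of the assay and not a number. Hexyl in place of phenyl gives an at least 1.8-fold higher number from compound 3 to compound 4 (0.26 log units; that floor lies within the scatter), so this change is not shown to matter, whereas hexyl in place of butylamino gives an at least 16-fold higher number from compound 2 to compound 4 (1.22 log units; beyond the scatter), so a plain hexyl chain stands clearly apart from butylamino at this position. The step from compound 1 to compound 4 cannot be read, since both values are limits: the limit of > 200000 nM in this assay, at which 2 of the 4 values shown sit.

As far as these compounds go, how far hexyl and octyl truly differ remains open. So does whether a plain butyl chain would reach this limit or fall nearer to butylamino.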